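The source may report more compounds than this note shows. Statements on the series, on what has been measured and on what is new or still open speak of the compounds shown alone.

In a functional assay on SK-OV-3 cells (Homo sapiens) for antiproliferative activity, read by MTT assay, with a stated time of 72 h (on this read-out lower numbers stand for stronger inhibition and higher numbers for weaker inhibition), two compounds built on the same core have been measured so far. Compound 1 `O=C(CCc1cccc2c1B(O)OC2)NC1CCCCC1`, with cyclohexyl on the amide nitrogen, gives > 100000 nM, which is a limit of the assay and not a number. For the measured compounds named here, compound 2 `O=C(CCc1cccc2c1B(O)OC2)Nc1ccc(F)cc1`, with 4-fluorophenyl in its place, gives 720 nM, the only actual number available, so it cannot yet be ranked against any other measured value. Going by the values given here, the one measured step is an at least 130-fold lower number from compound 1 to compound 2 (2.14 log units; beyond the scatter).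

Compound 3 `O=C(CCc1cccc2c1B(O)OC2)Nc1ccc(Br)cc1` has not been measured. It differs from compound 2 in one place: bromo in place of fluoro on an aromatic carbon. This is bromo in place of fluoro on an aromatic carbon, para to a large group.

The measured step bears on this only loosely. It was large, but it swapped the whole group on the nitrogen, whereas here the aromatic ring stays and a single substituent changes. A much smaller effect is therefore expected in this assay, with no firm direction. The estimated change is a 1.3-fold lower number from compound 2 to compound 3 (0.12 log units; within the scatter), which is no clear step beyond the scatter. For compound 3 the expected value is 550 nM, with an estimated range of 180 nM to 1800 nM.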

Compound 3, half-maximal inhibitory concentration: 9200 nM
Beside the measured number, compound 3's estimate is 17-fold (1.22 log units) below it, and the stated range ends below it.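

In this assay, the aromatic carbon para to a large group proves sensitive: bromo in place of fluoro there gives a 13-fold higher number from compound 2 to compound 3 (1.11 log units; beyond the scatter), a large step for the exchange of one heavy atom for another, while the rest of the molecule stays the same. The aromatic ring on the amide nitrogen still goes with a lower number than cyclohexyl, as 4-bromophenyl in place of cyclohexyl gives an at least 10-fold lower number from compound 1 to compound 3 (1.03 log units; beyond the scatter), but these compounds show that the size of that gain depends on the substituent the ring carries. The value of compound 1 is a limit of the assay and not a number: the limit of > 100000 nM in this assay, at which 1 of the 3 values shown sits.

The three compounds do not show what lies behind the gap between fluoro and bromo, so the cause of this step remains an open question. On these data alone, it is also open how a phenyl ring with hydrogen at that place, or one carrying chloro, methyl or methoxy, would read, and whether any of these would fall nearer to fluoro or to bromo.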